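This account rests on a few compounds, and the source may have more. Where it says the series, first, only, none or still open, it means among the compounds named here.

In an ADME assay on Vero cells (Chlorocebus sabaeus) for inhibition, read by sulforhodamine B assay, with a stated time of 48 h (on this read-out higher numbers stand for weaker inhibition of growth and lower numbers for stronger inhibition of growth), compound 1 `CC1=CC[C@H](C(C)(C)NC(=S)N/N=C/c2ccccc2)CC1` gives only a limit of > 100000 nM. Compound 2 `CC1=CC[C@H](C(C)(C)NC(=S)N/N=C/c2ccc(Cl)cc2)CC1` likewise gives only a limit, > 100000 nM. The step that the two limits leave unreadable from compound 1 to compound 2 cannot be sized, since both values sit at the limit of > 100000 nM in this assay, at which 2 of the 2 values shown sit. Compound 3 `CC1=CC[C@H](C(C)(C)NC(=S)N/N=C/c2cccs2)CC1` differs from compound 2 by thiophen-2-yl in place of 4-chlorophenyl on a carbon with a double bond to nitrogen. Among the measured compounds shown here, no measured step bears on this change, and the two limits give no size for any step, so no direction can be read. Compound 3 is expected to stay at the same limit, with the step that the limit leaves unreadable from compound 2 to compound 3 estimated as no change beyond the scatter. Compound 3 is therefore estimated at 150000 nM, within 60000 nM to 400000 nM.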

Compound 3, concentration for total growth inhibition: 13400 nM
Compound 3: the middle estimate sits 11-fold (1.05 log units) above what was measured, outside the stated range (below it).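

Thiophen-2-yl in place of 4-chlorophenyl on a carbon with a double bond to nitrogen gives a readable change in this assay: an at least 7.4-fold lower number from compound 2 to compound 3 (0.87 log units; beyond the scatter). Against the unsubstituted ring the result is an at least 7.4-fold lower number from compound 1 to compound 3 (0.87 log units; beyond the scatter), so the group at this place can move the read-out towards stronger inhibition of growth. Compounds 1 and 2 give only a limit, so both steps are minimum sizes: the limit of > 100000 nM in this assay, at which 2 of the 3 values shown sit.

The compounds shown leave open whether the sulfur or the five-membered ring goes with this step, which a furan-2-yl or pyrrol-2-yl group at the same place could separate. On these data alone, whether a methyl group on the thiophen-2-yl ring would keep the step also stays open.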